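From 4-methoxyphenyl to 5-methylfuran-2-yl: compound 1 to compound 3

The source may hold more compounds than are shown below. What is called first, only, known or untested is meant among the compounds shown, and "the series" means these compounds.

Among the compounds with values here, in a functional assay on A549 cells (Homo sapiens) for antiproliferative activity, read by sulforhodamine B assay, with a stated time of 48 h (on this read-out lower numbers stand for stronger inhibition and higher numbers for weaker inhibition), compound 1 (`COc1ccc(/C=C/C(=O)c2ccccc2-c2ccc(F)cc2)cc1`) gives 140 nM as the higher of the two numbers measured so far. Compound 2 (`COc1ccc(/C=C/C(=O)c2ccccc2-c2ccc(F)cc2)cc1O`) gives 65 nM in the same test. Within the data shown here, the only measured step is a 2.2-fold lower number from compound 1 to compound 2 (0.33 log units; beyond the scatter) for hydroxy in place of hydrogen on an aromatic carbon of the 4-methoxyphenyl group.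

Compound 3 (`Cc1ccc(/C=C/C(=O)c2ccccc2-c2ccc(F)cc2)o1`) is not yet measured. Its difference from compound 1 is 5-methylfuran-2-yl in place of 4-methoxyphenyl on a double-bonded chain carbon bound to a double-bonded chain carbon with the whole 4-methoxyphenyl group replaced. That measured step bears on this change only indirectly. Among the measured compounds shown here, compound 2 shows through a 2.2-fold lower number from compound 1 to compound 2 (0.33 log units; beyond the scatter) that the number moves with a small change on the group that leaves, but no measured step replaces that group. The size of the new step therefore rests on judgment, and a larger step than the measured one is plausible. The estimated change is a 2.5-fold higher number from compound 1 to compound 3 (0.40 log units; beyond the scatter) as a move toward a higher number, with wide uncertainty. For compound 3 the expected value is 350 nM with an estimated range from 110 nM to 1200 nM as working figures.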

Compound 3, half-maximal inhibitory concentration: 31000 nM
Compound 3: middle estimate off by 89-fold (1.95 log units), on the low side; the whole stated range lies below it.
By their numbers in this assay, from the lowest: compound 2; then compound 1; then compound 3.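

In this assay, the group on the double-bonded chain carbon bound to a double-bonded chain carbon proves far from interchangeable: 5-methylfuran-2-yl in place of 4-methoxyphenyl gives a 220-fold higher number from compound 1 to compound 3 (2.35 log units; beyond the scatter), a much larger move than a 2.2-fold lower number from compound 1 to compound 2 (0.33 log units; beyond the scatter) for hydroxy in place of hydrogen. The earlier pair showed only a modest shift from a small edit to this group, whereas compound 3 shows that exchanging the whole group, with the rest of the structure unchanged, can move the number far upward. The data at hand offer nothing that accounts for the size of this step.

Within the data shown here, the single step swaps a six-membered aromatic ring of carbon only for a five-membered aromatic ring with 1 hetero atom and also exchanges the groups carried on the ring, so it remains open which of these differences carries the step. As far as these compounds go, an unsubstituted furan-2-yl, a thiophen-2-yl or a plain phenyl at this place would help divide the step into its parts, and it also remains open whether a hydroxy group would lower the number on rings other than the 4-methoxyphenyl group.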